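Notes on the amide series: compound 2 to compound 3

The source may hold more compounds than are shown below. What is called first, only, known or untested is meant among the compounds shown, and "the series" means these compounds.

Compound 1 `COc1cc(/C=C/C(=O)c2cccc(NC(=O)c3cccs3)c2)ccc1O` and compound 2 `COc1cc(/C=C/C(=O)c2cccc(NC(=O)c3ccc(Cl)c(Cl)c3)c2)ccc1O` share one core and differ only in the group on the carbonyl carbon of the amide. In a functional assay on HUVEC cells (Homo sapiens) for inhibition, tested at 10 ug/mL (on this read-out lower numbers stand for a weaker effect and higher numbers for a stronger effect at the one concentration tested), compound 1 gives 90% and compound 2 gives 45%. Compound 2 therefore stands lowest of the two numbers, with compound 1 the nearest and higher by a margin beyond the scatter. Among the compounds with values here, the only measured step, a number 45 percentage points lower from compound 1 to compound 2 (beyond the scatter), is large.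

Compound 3 `COc1cc(/C=C/C(=O)c2cccc(NC(=O)C(C)C)c2)ccc1O` is not yet measured. It differs from compound 2 as follows: isopropyl in place of 3,4-dichlorophenyl on a carbonyl carbon. Within the data shown here, the same place is altered as in the one measured step, but there an aromatic ring was exchanged for another aromatic ring, whereas here a ring leaves and an isopropyl enters. That step shows the read-out is sensitive to what sits on this carbonyl carbon, but it does not fix the direction for a non-ring group. Compound 2 sits at 45%, and compound 1, which carries a smaller ring, gives 90%; on that basis compound 3 is expected to land near compound 2, if anything somewhat above it, though with wide uncertainty. The estimated step is a number 10 percentage points higher from compound 2 to compound 3 (within the scatter). For compound 3 the expected value is 55%, estimated between 25% and 85%.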

Compound 3, a percentage reported as inhibition, at one concentration (the size of the read-out at that concentration, not a potency): 56%
The estimate for compound 3 lay 1 percentage points below the measured number; low and high end bracket the measured number.
By their numbers in this assay, from the lowest: compound 2; then compound 3; then compound 1.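

In this assay, the carbonyl carbon of the amide does not need a ring to carry a number above that of compound 2: isopropyl in place of 3,4-dichlorophenyl gives a number 11 percentage points higher from compound 2 to compound 3 (beyond the scatter), a modest step. Isopropyl in place of thiophen-2-yl gives a number 34 percentage points lower from compound 1 to compound 3 (beyond the scatter), a large step, so the ringless group ranks in the middle of the two ring-bearing groups and the presence of a ring alone does not sort these three compounds. Nothing available gives a reason for this order.

As far as these compounds go, it remains open whether the low number of compound 2 belongs to the two chlorine atoms or to the six-membered ring itself, and an unsubstituted phenyl or a furan-2-yl on this carbonyl carbon would help to separate the two. From the compounds shown here alone, it also remains open how a longer alkyl chain, or a chain ending in an amine or a carboxylic acid, would compare with isopropyl in this assay, where every number so far comes from the one concentration tested.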